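Compound 4: ethynyl in place of thiophen-2-yl

This account rests on a few compounds, and the source may have more. Where it says the series, first, only, none or still open, it means among the compounds named here.

Measured in an ADME assay on BJ cells (Homo sapiens), read by MTT assay, with a stated time of 72 h; on this read-out higher numbers stand for weaker inhibition and lower numbers for stronger inhibition:
- compound 1 `C#Cc1cn([C@@H]2O[C@H](CO)[C@@H](O)[C@H]2O)c2ncnc(OC)c12`: 98400 nM
- compound 2 `Nc1nc(N)c2c(-c3cccs3)cn([C@@H]3O[C@H](CO)[C@@H](O)[C@H]3O)c2n1`: > 100000 nM (a limit)
- compound 3 `COc1nc(N)nc2c1c(-c1cccs1)cn2[C@@H]1O[C@H](CO)[C@@H](O)[C@H]1O`: 99900 nM

Compound 3 gives 99900 nM, which lies within the scatter of compound 1. Within the data shown here, the only other value is a limit, recorded as the limit of > 100000 nM in this assay, at which 1 of the 3 values shown sits.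

The next compound is compound 4 `C#Cc1cn([C@@H]2O[C@H](CO)[C@@H](O)[C@H]2O)c2nc(N)nc(OC)c12`, reached by one change: ethynyl in place of thiophen-2-yl on an aromatic carbon. In words, this is ethynyl in place of thiophen-2-yl on an aromatic carbon.

Among the measured compounds shown here, no measured step makes this exchange. For the measured compounds named here, the one step available, a number no higher from compound 2 to compound 3 (the limit leaves the size open), is methoxy in place of amino, and its size stays open. Compound 1 already carries ethynyl and gives 98400 nM, so ethynyl alone does not point to a marked shift in this assay. No step beyond the scatter is therefore expected.

The expected change is a 1.2-fold lower number from compound 3 to compound 4 (0.10 log units; within the scatter), estimated to fall within the scatter. For compound 4 the estimate is 80000 nM, with an expected range of 20000 nM to 100000 nM.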

Compound 4, half-maximal inhibitory concentration: > 100000 nM
Compound 4 gave a limit, no number; the forecaster's own chance of this, stated with the estimate: 40%; middle value at least 1.2-fold (0.09 log units) from the limit.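

In this assay compound 4 gives > 100000 nM, a limit and not a number, and it joins compound 2 there: the limit of > 100000 nM in this assay, at which 2 of the 4 values shown sit. Ethynyl and thiophen-2-yl cannot be ordered at this aromatic carbon, since the step for that exchange cannot be read, and neither group gives a reading of stronger inhibition here. On the core that already carries ethynyl, amino in place of hydrogen on an aromatic carbon gives an at least 1.0-fold higher number from compound 1 to compound 4 (0.00 log units; that floor lies within the scatter), so this exchange shows no stronger inhibition.

Ethynyl in place of thiophen-2-yl on an aromatic carbon gives a number no lower from compound 3 to compound 4 (the limit leaves the size open) and the compounds shown leave open whether any group at this aromatic carbon would give a number clearly lower than the limit. A carboxylic acid, an amine or a longer chain such as propyl could test this.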